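A Smaller Amide Group at the Assay Limit

The compounds below may be only part of what the source reports. "The series", "measured", "known", "first", "only" and "open" are said of these compounds alone.

Values from an ADME assay on SH-SY5Y cells (Homo sapiens) for cytotoxicity, read by MTT assay, with a stated time of 48 h (a lower number here means a stronger inhibitor, a higher number a weaker inhibitor), follow
Compound 1 `COc1ccc(C(=O)/C=C/c2ccc(C(=O)N3CCCC3)cc2)c(O)c1` gives > 100000 nM
Compound 2 `COc1ccc(C(=O)/C=C/c2ccc(C(=O)Nc3cc([N+](=O)[O-])ccc3O)cc2)c(O)c1` gives > 100000 nM

The value of compound 1 (> 100000 nM) is a limit of the assay and not a number. Going by these compounds, compound 2 (> 100000 nM) also has only a limit, so its exact place on the scale stays unknown.

Compound 3 (`COc1ccc(C(=O)/C=C/c2ccc(C(=O)NC(C)C)cc2)c(O)c1`) keeps the shared core and carries isopropyl in place of 2-hydroxy-5-nitrophenyl on an amide-type nitrogen. Going by the values given here, no measured pair yet shows the size of a single change in this assay for this series. Compound 1 and compound 2 both sit at one limit (the limit of > 100000 nM in this assay, at which 2 of the 2 values shown sit), so no step beyond the scatter is expected in this assay for this change. The expected size of the step is small (a number no higher from compound 2 to compound 3 (the limit leaves the size open)). The estimate for compound 3 is 100000 nM with an expected range from 50000 nM to 200000 nM and a good chance of another limit.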

Compound 3, half-maximal inhibitory concentration: > 100000 nM
Compound 3: only a limit was reported; the forecaster's own chance of this, stated with the estimate: 80%; the middle value sits exactly at the limit.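

Going by these compounds alone, compound 1, compound 2 and compound 3 all give a limit and not a number, so no step among them can be read: the limit of > 100000 nM in this assay, at which 3 of the 3 values shown sit. The compounds shown leave open how far each value lies beyond that limit and whether changing the amide group shifts the result in this assay.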